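The source may hold more compounds than are shown below. What is called first, only, known or untested is meant among the compounds shown, and "the series" means these compounds.

Measured so far:
- compound 1, `Clc1ccc2c(NCCNc3nccc(Nc4ccccc4)n3)ccnc2c1`: "not active" (no number reported)
- compound 2, `Fc1ccc(Nc2ccnc(NCCCNc3ccnc4cc(Cl)ccc34)n2)cc1`: 13700 nM
- compound 3, `Clc1ccc(Nc2ccnc(NCCCCNc3ccnc4cc(Cl)ccc34)n2)cc1`: 11000 nM

In an ADME assay on Vero cells (Chlorocebus sabaeus) for cytotoxicity, read by neutral red uptake, with a stated time of 72 h (on this read-out higher numbers stand for weaker inhibition and lower numbers for stronger inhibition), compound 1 gives "not active" (no number reported), which is a report without a single number rather than a measured value. Compound 2 gives 13700 nM in this assay. Compound 3 gives 11000 nM in this assay; of the two compounds with a number it has the lower one, but compound 2 sits within the scatter of it, so the two cannot be ordered.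

Compound 4, `COc1ccc(Nc2ccnc(NCCCCNc3ccnc4cc(Cl)ccc34)n2)cc1`, has not yet been measured in this assay. It differs from compound 3 in one place: methoxy in place of chloro on an aromatic carbon. Among the measured compounds shown here, no step between measured compounds is available that shows what such an exchange does in this assay, so there is nothing to carry over directly. The two numbers in hand lie close together despite different chain lengths and a different halogen on the aniline ring, which suggests this cytotoxicity read-out is not very sensitive to changes at that end of the molecule. A step of no size beyond the scatter is expected from compound 3 to compound 4, as a 1.1-fold higher number from compound 3 to compound 4 (0.04 log units; within the scatter). Compound 4 is therefore estimated at 12000 nM, with a range from 5000 nM to 30000 nM.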

Compound 4, half-maximal inhibitory concentration: 11100 nM
Beside the measured number, compound 4's estimate is 1.1-fold (0.03 log units) above it; the range from low to high includes it.
By their numbers in this assay, from the lowest: compounds 3, 4 and 2 (each within the scatter of the next).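

In this assay, among the compounds shown here, the exchange of 4-chlorophenyl for 4-methoxyphenyl gives the first step between compounds that differ in one place: a 1.0-fold higher number from compound 3 to compound 4 (0.00 log units; within the scatter). At this aromatic carbon, para to a large group, the entry of methoxy adds one heavy atom and one hydrogen-bond acceptor, yet the number shows no change beyond the scatter. Nothing measured bears on why this exchange leaves the number in place.

This is a single exchange at a single position, so it does not show whether the insensitivity holds for other groups there, such as an amine or a carboxylic acid. Going by these compounds, the effect of a longer chain, with the aniline substituent held fixed, also remains open.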